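Solubility Steps Toward Compound 4

This account rests on a few compounds, and the source may have more. Where it says the series, first, only, none or still open, it means among the compounds named here.

Measured compounds:
compound 1: `COc1ccc(F)cc1CNCCCNc1ccnc2cc(Cc3ccc(C#N)cc3)ccc12` – 4200 nM
compound 2: `CC(C)(C)c1ccc(-c2ccc3c(NCCCNCc4ccco4)ccnc3c2)cc1` – 32000 nM
compound 3: `CCC(CC)c1ccc2c(NCCCNCc3ccco3)ccnc2c1` – 4200 nM

In a physicochemical assay for solubility, with a stated time of 18 h, at pH 7.4 (on this read-out higher numbers stand for higher solubility and lower numbers for lower solubility), compound 3 gives 4200 nM, which stands level with compound 1 at the digits shown; these two are together the lowest of the three numbers, while compound 2 gives the highest value. Going by the values given here, the only single-point step among the measured compounds is a 7.6-fold lower number from compound 2 to compound 3 (0.88 log units; beyond the scatter), a modest drop when a pentan-3-yl replaced a 4-(tert-butyl)phenyl.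

Compound 4, `N#Cc1ccc(Cc2ccc3c(NCCCNCc4ccco4)ccnc3c2)cc1`, differs from compound 3 by 4-cyanobenzyl in place of pentan-3-yl on an aromatic carbon. Among the compounds with values here, no measured step follows exactly this change. Compound 1 carries the same 4-cyanobenzyl group on the same position of the core and gives 4200 nM, no different from compound 3 at the digits shown, though compound 1 also differs in its side chain. Within the data shown here, the one measured step suggests an aryl group may raise the number, but compound 1 gives no sign of that. Compound 4 is therefore expected to show a 1.2-fold higher number from compound 3 to compound 4 (0.08 log units; within the scatter), an estimated 5000 nM with a range of 1500 nM to 16000 nM.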

Compound 4, solubility: 4200 nM
Compound 4: middle estimate off by 1.2-fold (0.08 log units), on the high side; measured number inside the range.
By their numbers in this assay, from the lowest: compounds 1, 3 and 4 (each within the scatter of the next); then compound 2.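

In this assay the aromatic carbon now has a direct reading for this exchange, with no change at the digits printed from compound 3 to compound 4 (within the scatter) when 4-cyanobenzyl takes the place of pentan-3-yl. Set against 4-(tert-butyl)phenyl at that same place, 4-cyanobenzyl gives a 7.6-fold lower number from compound 2 to compound 4 (0.88 log units; beyond the scatter) and so, despite carrying a six-membered aromatic ring, does not hold the number at the level of compound 2. On the side chain, the exchange of 5-fluoro-2-methoxyphenyl for furan-2-yl gives no change at the digits printed from compound 1 to compound 4 (within the scatter) with 4-cyanobenzyl on the core.

As far as these compounds go, it remains open whether an amine, a carboxylic acid or a longer chain on this aromatic carbon would move the number away from that of compound 4. Nothing available here accounts for any of these numbers.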